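The compounds below may be only part of what the source reports. "The series", "measured", "known", "first", "only" and "open" are said of these compounds alone.

Of the compounds shown here, three sharing one core have been tested in a functional assay on HEK293 cells for agonist activity at G-protein coupled receptor 39 (Homo sapiens), read by scintillation proximity assay and inositol phosphate accumulation, with a stated time of 75 min, in the presence of a further agent that is not named here; a lower number here means that less compound is needed, a higher number that more compound is needed for the effect. Compound 1 `Cc1nn(-c2ncnc3nc[nH]c23)c2c1C(OCCc1ccccc1)CC(=O)N2` gives 3 nM. Compound 3 `Cc1nn(-c2ncnc3nc[nH]c23)c2c1C(OCc1ccccc1F)CC(=O)N2` gives 4 nM. Compound 2 `Cc1cc(C)n(CCOC2CC(=O)Nc3c2c(C)nn3-c2ncnc3nc[nH]c23)n1` gives 16 nM. Compound 1 has the lowest number of the three: its nearest neighbour is compound 3, with the step of a 1.3-fold higher number from compound 1 to compound 3 (0.12 log units; within the scatter), and the furthest is compound 2, with the step of a 5.3-fold higher number from compound 1 to compound 2 (0.73 log units; beyond the scatter).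

The not-yet-measured compound 4 `Cc1nn(-c2ncnc3nc[nH]c23)c2c1C(OCc1ccc(F)cc1)CC(=O)N2` differs from compound 1 in one place: 4-fluorophenyl in place of benzyl on a saturated chain carbon bound to an oxygen on a saturated carbon. The comparison that bears most directly on this change is the step to compound 3, where another fluorine-bearing ring replaced benzyl at the same place and gave a 1.3-fold higher number from compound 1 to compound 3 (0.12 log units; within the scatter), a change inside the scatter. The step of a 5.3-fold higher number from compound 1 to compound 2 (0.73 log units; beyond the scatter) shows that the end of the chain can matter modestly, but that change replaced the ring itself with a different ring and is of another kind. Compound 4 is therefore expected to show a step of about a 1.7-fold higher number from compound 1 to compound 4 (0.22 log units; within the scatter), which would lie within the usual scatter. The estimate for compound 4 in this assay is 5 nM, with a range from 2 nM to 15 nM.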

Compound 4, half-maximal effective concentration: 1 nM
For compound 4 the middle estimate is 5.0-fold (0.70 log units) above the measured one; the measured number lies below the stated range.
By their numbers in this assay, from the lowest: compound 4; then compounds 1 and 3 (each within the scatter of the next); then compound 2.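

In this assay, where the fluorine sits on the ring matters: 2-fluorophenyl and 4-fluorophenyl differ only in that place, yet the change between them gives a 4.0-fold lower number from compound 3 to compound 4 (0.60 log units; beyond the scatter). Compound 3 alone had left the swap away from benzyl looking silent, whereas the 4-fluorophenyl group gives a 3.0-fold lower number from compound 1 to compound 4 (0.48 log units; beyond the scatter), so this end of the chain responds to a smaller edit than the change of ring seen in compound 2. With the pyrazole-bearing chain as the reference, the new group gives a 16-fold lower number from compound 2 to compound 4 (1.20 log units; beyond the scatter), and compound 4 now holds the lowest number of the set, its steps to all the others lying beyond the scatter.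

The step from compound 1 also swaps phenethyl for 4-fluorobenzyl, so it joins a change in the chain with the arrival of fluorine, and a 4-fluorophenethyl group or a 4-chlorobenzyl group would be needed to tell these apart. Nothing available here explains why the place of the fluorine changes the number.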